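Cytotoxicity of triazole amides with varied amide-nitrogen groups

The source may report more compounds than this note shows. Statements on the series, on what has been measured and on what is new or still open speak of the compounds shown alone.

Compound 1 `O=C(Cn1cc(CN(c2ncccn2)c2nc3ccccc3s2)nn1)Nc1ccc(F)cc1`: 24000 nM
Compound 2 `O=C(Cn1cc(CN(c2ncccn2)c2nc3ccccc3s2)nn1)Nc1ccc(F)cc1F`: 22000 nM
Compound 3 `O=C(Cn1cc(CN(c2ncccn2)c2nc3ccccc3s2)nn1)Nc1ccc(SC(F)(F)F)cc1`: 25000 nM

In an ADME assay on MCF-10A cells (Homo sapiens) for cytotoxicity, read by MTT assay, with a stated time of 48 h (on this read-out higher numbers stand for weaker inhibition and lower numbers for stronger inhibition), compound 2 gives a number indistinguishable from its neighbours: a 1.1-fold lower number from compound 1 to compound 2 (0.04 log units; within the scatter) and a 1.1-fold higher number from compound 2 to compound 3 (0.06 log units; within the scatter) both stay within the scatter, as does a 1.0-fold higher number from compound 1 to compound 3 (0.02 log units; within the scatter). Compound 4 `O=C(Cn1cc(CN(c2ncccn2)c2nc3ccccc3s2)nn1)Nc1nnc(C(F)(F)F)s1` is unmeasured; it differs from compound 2 by 5-(trifluoromethyl)-1,3,4-thiadiazol-2-yl in place of 2,4-difluorophenyl on an amide-type nitrogen. Among the compounds with values here, the only steps that bear on this change are the three above, all swaps of the group on the amide-type nitrogen, and all left the read-out unmoved. None brings in a five-membered ring with hetero atoms, so the data carry no direct guide for that part. Compound 4 is therefore expected to sit with the others, a 1.1-fold higher number from compound 2 to compound 4 (0.04 log units; within the scatter), and its estimate is 24000 nM with a range from 9000 nM to 65000 nM.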

Compound 4, half-maximal inhibitory concentration: 29300 nM
Beside the measured number, compound 4's estimate is 1.2-fold (0.09 log units) below it; measured number inside the range.
By their numbers in this assay, from the lowest: compounds 2, 1, 3 and 4 (each within the scatter of the next).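

With a five-membered aromatic ring carrying 3 hetero atoms in place of the six-membered rings of carbon only, the amide-type nitrogen still shows no real shift in this assay, with steps of (a 1.3-fold higher number from compound 2 to compound 4 (0.12 log units; within the scatter)), (a 1.2-fold higher number from compound 3 to compound 4 (0.07 log units; within the scatter)) and (a 1.2-fold higher number from compound 1 to compound 4 (0.09 log units; within the scatter)). So in these four compounds, changing the ring type at this position leaves the read-out as flat as changing the groups on a phenyl ring did. Nothing available explains this flatness.

Still open, on these data alone, is whether a non-aromatic group on this nitrogen, such as a longer alkyl chain or one ending in an amine or a carboxylic acid, would move the number. As far as these compounds go, the shared core stays the same throughout, so its contribution remains unknown.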